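A Fluoro Step from Compound 3

The compounds below may be only part of what the source reports. "The series", "measured", "known", "first", "only" and "open" are said of these compounds alone.

Of the compounds shown here, three have been measured in a functional assay on MCF7 cells (Homo sapiens) for antiproliferative activity, read by sulforhodamine B assay, with a stated time of 72 h; on this read-out lower numbers stand for stronger inhibition and higher numbers for weaker inhibition. Compound 1 `COc1c(OC(C)C)cc2occ(-c3csc4ccccc34)c(=O)c2c1O` gives only a limit, > 10000 nM. Compound 2 `COc1cc2occ(-c3csc4ccccc34)c(=O)c2cc1OC` also gives only a limit, > 10000 nM. Going by the values given here, compound 3 `O=C(/C=C/c1csc2ccccc12)c1ccccc1O` is the one compound of the three with an actual number, 6600 nM, and it has a different structure from the other two. Its standing therefore rests on a single value set against two limits.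

The next compound to be tested is compound 4 `O=C(/C=C/c1csc2ccccc12)c1cc(F)ccc1O`, which differs from compound 3 in one place: fluoro in place of hydrogen on an aromatic carbon. The change is fluoro in place of hydrogen on an aromatic carbon, para to a hydroxy group.

Among the compounds with values here, no two measured compounds differ in only one place, so the series gives no direct guide to the size of this change. The expectation starts from compound 3 at 6600 nM and assumes that a single substitution will shift it only a little. The estimated change, a 1.3-fold lower number from compound 3 to compound 4 (0.12 log units; within the scatter), is expected to stay within the usual scatter of this assay, leaning slightly toward stronger inhibition. For compound 4 the estimated value is 5000 nM, with an expected range from 2000 nM to 10000 nM.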

Compound 4, half-maximal inhibitory concentration: > 10000 nM
Compound 4: only a limit was reported; the forecaster's own chance of this, stated with the estimate: 12%; middle value at least 2.0-fold (0.30 log units) from the limit.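

In this assay, going by these compounds alone, fluoro in place of hydrogen on an aromatic carbon, para to a hydroxy group, gives the first step that can be read: an at least 1.5-fold higher number from compound 3 to compound 4 (0.18 log units; that floor lies within the scatter). The earlier compounds shown here offered no such comparison, and this step shows that the fluoro group brings no measurable gain at this position, since compound 4 no longer gives a number at all, though the floor of the step alone does not establish a loss beyond the scatter. The true size of the step cannot be stated, because the result for compound 4 runs into the end of the read-out: the limit of > 10000 nM in this assay, at which 3 of the 4 values shown sit.

From the compounds shown here alone, what remains open is whether this position rejects substitution in general or fluoro in particular, as a chloro, methoxy or amine group at the same place could separate those two readings. Going by these compounds, it is also open how much the hydroxy group itself contributes, a question that a methoxy group in its place on the core of compound 3 would address directly.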